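The compounds below may be only part of what the source reports. "The series", "measured", "known", "first", "only" and "open" are said of these compounds alone.

Compound 3 `COCOc1ccc(C2CC(=O)c3ccc(OC)cc3O2)cc1CC=C(C)C` gives 25100 nM in an assay on isolated protein for inhibition of Aromatase (Homo sapiens) (on this read-out lower numbers stand for stronger inhibition and higher numbers for weaker inhibition), the highest of the three numbers, although its gap to compound 1 lies within the scatter while its gap to compound 2 lies beyond it. Compound 1 `COCOc1ccc2c(c1)OC(c1ccc(OCOC)c(CC=C(C)C)c1)CC2=O` gives 14000 nM and compound 2 `COCOc1ccc2c(c1)OC(c1ccc(OC)c(CC=C(C)C)c1)CC2=O` gives 7670 nM in this assay. Compound 4 `COc1ccc2c(c1)OC(c1ccc(OC)c(CC=C(C)C)c1)CC2=O` differs from compound 3 by hydrogen in place of methoxy on a saturated chain carbon bound to an oxygen on an aromatic ring. The same change has been measured once, as a 1.8-fold lower number from compound 1 to compound 2 (0.26 log units; within the scatter), and a change of the same kind gave a 1.8-fold higher number from compound 1 to compound 3 (0.25 log units; within the scatter). Both lie within the scatter, so the step of a 1.8-fold lower number from compound 3 to compound 4 (0.25 log units; within the scatter) is expected to be small and probably downward. Compound 4 is therefore estimated at 14000 nM, with a range from 6000 nM to 33000 nM.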

Compound 4, half-maximal inhibitory concentration: 3670 nM
Compound 4: the middle estimate sits 3.8-fold (0.58 log units) above what was measured; the whole stated range lies above it.
By their numbers in this assay, from the lowest: compound 4; then compounds 2, 1 and 3 (each within the scatter of the next, the first and the last beyond it).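

In this assay the change from methoxymethoxy to methoxy now moves the number beyond the scatter in both pairs read, a 6.8-fold lower number from compound 3 to compound 4 (0.84 log units; beyond the scatter) and a 2.1-fold lower number from compound 2 to compound 4 (0.32 log units; beyond the scatter), whereas both earlier steps stayed within it. The size of the same change therefore depends on the core that carries it: the same change on two cores in this assay, a 1.8-fold lower number (0.26 log units; within the scatter) from compound 1 to compound 2 and a 6.8-fold lower number (0.84 log units; beyond the scatter) from compound 3 to compound 4, 3.7-fold (0.57 log units) apart, beyond the scatter of two such steps. The second pair of steps shows the same dependence: the same change on two cores in this assay, a 1.8-fold higher number (0.25 log units; within the scatter) from compound 1 to compound 3 and a 2.1-fold lower number (0.32 log units; beyond the scatter) from compound 2 to compound 4, 3.7-fold (0.57 log units) apart, beyond the scatter of two such steps.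

On these data alone, what a hydroxyl or an ethoxy group would give at these places stays open. So does whether a larger step at one place holds on other cores.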